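The source may hold more compounds than are shown below. What is called first, only, known or untested is meant among the compounds shown, and "the series" means these compounds.

Compound 1 `O=C(Nc1cccc(-n2cc(-c3ccncc3)c(-c3ccc(Cl)c(O)c3)n2)c1)Nc1cccc(C(F)(F)F)c1` gives > 32500 nM in a functional assay on MOLT-4 cells (Homo sapiens) for inhibition, read by sulforhodamine B assay, with a stated time of 48 h; on this read-out higher numbers stand for lower toxicity in this test and lower numbers for higher toxicity in this test; this is a limit of the assay. Compound 2 `O=C(Nc1cccc(-n2cc(-c3ccncc3)c(-c3ccc(Cl)c(O)c3)n2)c1)Nc1ccc(Cl)c(Cl)c1` gives > 32500 nM in this assay, again a limit. Compound 3 `COc1cc(-c2nn(-c3cccc(NC(=O)Nc4ccc(Cl)c(C(F)(F)F)c4)c3)cc2-c2ccncc2)ccc1Cl` gives > 32500 nM in this assay, also a limit.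

Compound 3 therefore stands at the edge of what this test can report, together with every other value shown, since (the limit of > 32500 nM in this assay, at which 3 of the 3 values shown sit). Compound 4 `O=C(Nc1cccc(-n2cc(-c3ccncc3)c(-c3ccc(Cl)c(O)c3)n2)c1)Nc1ccc(Cl)c(C(F)(F)F)c1` differs from compound 3 by hydrogen in place of methyl on an oxygen on an aromatic ring. Within the data shown here, the one measured step, a step that the two limits leave unreadable from compound 1 to compound 2, is unreadable, so no measured change gives a size for the move from compound 3 to compound 4. Compound 1 and compound 2, which carry the hydroxy group, both sit at the limit. Compound 4 is expected to stay at that limit as well, at about 60000 nM (range 20000 nM to 200000 nM), meaning an expected step that the limit leaves unreadable from compound 3 to compound 4.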

Compound 4, concentration lethal to 50% of the cells: > 32500 nM
Compound 4: only a limit was reported (the forecaster's own chance of this, stated with the estimate: 85%); the middle value does not contradict the limit.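

Compound 4 adds no readable step to compound 1, compound 2 or compound 3, because all four stand at the same edge of the test: the limit of > 32500 nM in this assay, at which 4 of the 4 values shown sit. From the compounds shown here alone, how far each compound lies beyond that limit, and whether any of these group changes alters toxicity, stays open.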